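Compound 3: a difluorophenyl ketone from a methoxyphenyl parent

The source may hold more compounds than are shown below. What is called first, only, known or untested is meant among the compounds shown, and "the series" means these compounds.

Two pyrazole-linked enones have been measured. Compound 1 `COc1cc(-c2cc(/C=C/C(=O)c3ccc(N)cc3)[nH]n2)cc(OC)c1OC` gives -9% in a functional assay on SK-OV-3 cells (Homo sapiens) for cytotoxicity, read by sulforhodamine B assay, with a stated time of 48 h, tested at 10 uM; on this read-out higher numbers stand for a weaker effect at the one concentration tested and lower numbers for a stronger effect. Compound 2 `COc1ccc(C(=O)/C=C/c2cc(-c3cc(OC)c(OC)c(OC)c3)n[nH]2)cc1` gives 18% in this assay, the highest of the two numbers, the step of a number 27 percentage points higher from compound 1 to compound 2 (beyond the scatter) being beyond the scatter. Compound 3 `COc1cc(-c2cc(/C=C/C(=O)c3ccc(F)c(F)c3)[nH]n2)cc(OC)c1OC` is not yet measured; it differs from compound 2 as follows: 3,4-difluorophenyl in place of 4-methoxyphenyl on a carbonyl carbon. For the measured compounds named here, the one measured step, the change of amino to methoxy from compound 1 to compound 2, concerns a different kind of substitution and does not bear directly on the exchange of a 4-methoxyphenyl for a 3,4-difluorophenyl on the carbonyl carbon. Going by the values given here, with no step that bears on this change, compound 3 is expected to differ from compound 2 by a number 3 percentage points lower from compound 2 to compound 3 (within the scatter), a step within the scatter. The estimate for compound 3 in this assay is 15%, ranging from -15% to 45%.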

Compound 3, a percentage reported as activity, at one concentration (the size of the read-out at that concentration, not a potency): 17%
Compound 3: middle estimate off by 2 percentage points, on the low side; low and high end bracket the measured number.
By their numbers in this assay, from the lowest: compound 1; then compounds 3 and 2 (each within the scatter of the next).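

On the carbonyl carbon, 3,4-difluorophenyl in place of 4-methoxyphenyl gives a number 1 percentage points lower from compound 2 to compound 3 (within the scatter) in this assay, so this position accepts either of these two quite different aryl groups without a change that can be read. Against the 4-aminophenyl group, the same 3,4-difluorophenyl gives a number 26 percentage points higher from compound 1 to compound 3 (beyond the scatter), which leaves compound 1 as the only one of the three set apart from both others, while compound 2 and compound 3 cannot be separated. Nothing at hand gives a reason for either step.

Going by these compounds, what a hydroxyl, an acetamide or a dimethylamino group would do on the phenyl ring at this carbonyl carbon remains open, and so does whether the amino group alone separates compound 1. The compounds shown also leave open how a single fluorine would compare with the 3,4-difluorophenyl group.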